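Halogen scan at the aromatic position: bromo follows chloro

The compounds below may be only part of what the source reports. "The series", "measured", "known", "first", "only" and "open" are said of these compounds alone.

Measured so far in a functional assay on PC-3 cells (Homo sapiens) for antiproliferative activity, read by sulforhodamine B assay, with a stated time of 48 h; on this read-out lower numbers stand for stronger inhibition and higher numbers for weaker inhibition:
compound 1, `CO/N=C1/C(=O)N(CCCCCCC(=O)NO)c2ccccc21`: 1670 nM
compound 2, `CO/N=C1/C(=O)N(CCCCCCC(=O)NO)c2ccc(F)cc21`: 1150 nM
compound 3, `CO/N=C1/C(=O)N(CCCCCCC(=O)NO)c2ccc(Cl)cc21`: 2330 nM

Compound 3 carries the highest number of the three. Its gap to compound 1 is small, a 1.4-fold higher number from compound 1 to compound 3 (0.14 log units; within the scatter), and lies within the scatter; its gap to compound 2 is larger, a 2.0-fold higher number from compound 2 to compound 3 (0.31 log units; beyond the scatter), and just beyond it. The fluoro step itself, a 1.5-fold lower number from compound 1 to compound 2 (0.16 log units; within the scatter), is within the scatter. All three compounds share the same core and the same hydroxamic acid chain; only the substituent on the aromatic carbon differs.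

Compound 4, `CO/N=C1/C(=O)N(CCCCCCC(=O)NO)c2ccc(Br)cc21`, is the next member of the halogen series. The change from compound 3 is bromo in place of chloro on an aromatic carbon.

Among the measured compounds shown here, the steps that bear on it are the two halogen replacements already in hand: hydrogen to chloro, a 1.4-fold higher number from compound 1 to compound 3 (0.14 log units; within the scatter), and fluoro to chloro, a 2.0-fold higher number from compound 2 to compound 3 (0.31 log units; beyond the scatter). Neither moves the number much, and the two halogens sit at the extremes of the small spread observed. With only three points there is no trend to extrapolate, so the step to compound 4 is expected to be small as well, most likely within the scatter, with a slight lean toward a higher number; the expected step is a 1.1-fold higher number from compound 3 to compound 4 (0.05 log units; within the scatter).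

For compound 4 in this assay the estimate is 2600 nM, with a range from 1300 nM to 5200 nM.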

Compound 4, half-maximal inhibitory concentration: 8910 nM
For compound 4 the middle estimate is 3.4-fold (0.53 log units) below the measured one; the whole stated range lies below it.
By their numbers in this assay, from the lowest: compounds 2, 1 and 3 (each within the scatter of the next, the first and the last beyond it); then compound 4.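

In this assay, this aromatic carbon proves less permissive than compound 1, compound 2 and compound 3 suggested: bromo in place of chloro gives a 3.8-fold higher number from compound 3 to compound 4 (0.58 log units; beyond the scatter), a larger step than any seen among those three. The same holds against the other two members, with a 5.3-fold higher number from compound 1 to compound 4 (0.73 log units; beyond the scatter) and a 7.7-fold higher number from compound 2 to compound 4 (0.89 log units; beyond the scatter), so compound 4 carries the highest number in the series, beyond the scatter from each of the others. The change is only one halogen atom for another, with no ring, hydrogen-bond donor, hydrogen-bond acceptor or net charge entering or leaving, yet the number rises clearly, so the small spread among hydrogen, fluoro and chloro does not extend to bromo.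

The compounds shown leave open whether iodo would continue this rise, and whether methyl, methoxy or trifluoromethyl on the same carbon would follow bromo or stay with the smaller substituents. They also leave open whether a shorter or longer chain carrying the hydroxamic acid would change the size of the bromo step.

Nothing available here accounts for the size of the bromo step.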